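From 5-methylpyrazin-2-yl to pyrazin-2-yl: notes on compound 4

This account rests on a few compounds, and the source may have more. Where it says the series, first, only, none or still open, it means among the compounds named here.

Measured in an ADME assay on MDCKII-LE cells (Canis lupus familiaris) for permeability; a higher number here means that the compound crosses the layer faster, a lower number that the compound crosses the layer more slowly:
- compound 1 `Cc1cnc(NC(=O)c2cc(Oc3cnc(C(=O)N(C)C)cn3)c3cc(C)oc3c2)cn1`: 22.3 10^-6 cm/s
- compound 2 `CCN(C)C(=O)c1cnc(Oc2cc(C(=O)Nc3cnc(C)cn3)cc3oc(C)cc23)cn1`: 24.1 10^-6 cm/s
- compound 3 `Cc1cnc(NC(=O)c2cc(Oc3cnc(C(=O)N4CCCCC4)cn3)c3cc(C)oc3c2)cn1`: 13.3 10^-6 cm/s

Compound 1 cannot be separated from the other two on these numbers. The measured steps are a 1.1-fold higher number from compound 1 to compound 2 (0.03 log units; within the scatter) and a 1.7-fold lower number from compound 1 to compound 3 (0.22 log units; within the scatter), and both lie within the scatter.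

Compound 4 `Cc1cc2c(Oc3cnc(C(=O)N(C)C)cn3)cc(C(=O)Nc3cnccn3)cc2o1` differs from compound 1 as follows: hydrogen in place of methyl on an aromatic carbon. This is hydrogen in place of methyl on an aromatic carbon, turning 5-methylpyrazin-2-yl into pyrazin-2-yl. Going by the values given here, no measured step touches that group, so the evidence is indirect. The nearest analogy is another exchange of methyl and hydrogen, elsewhere in the molecule, which gave a 1.1-fold higher number from compound 1 to compound 2 (0.03 log units; within the scatter). The largest measured step, a 1.8-fold lower number from compound 2 to compound 3 (0.26 log units; within the scatter), also stays within the scatter.

No change beyond the scatter is therefore expected in this assay. The expected step is a 1.1-fold lower number from compound 1 to compound 4 (0.03 log units; within the scatter). The estimate for compound 4 is 21 10^-6 cm/s, with an expected range of 12 10^-6 cm/s to 36 10^-6 cm/s.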

Compound 4, apparent permeability: 30 10^-6 cm/s
Estimate against measurement, compound 4: 1.4-fold (0.15 log units) below; measured number inside the range.
By their numbers in this assay, from the lowest: compounds 3, 1, 2 and 4 (each within the scatter of the next, the first and the last beyond it).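

Going by these compounds alone, this is the first reading at this position: in this assay, hydrogen in place of methyl on this aromatic carbon gives a 1.3-fold higher number from compound 1 to compound 4 (0.13 log units; within the scatter), so 5-methylpyrazin-2-yl and pyrazin-2-yl cannot be separated on this read-out. The earlier steps shown here touched only the group on the carbonyl carbon of the other amide, and this exchange on the pyrazine ring likewise stays within the scatter. Nothing shown accounts for the size of this step.

Still open, going by these compounds, is whether a group other than methyl on this aromatic carbon, such as methoxy, an amine or chlorine, would give a step beyond the scatter. Also open, on these data alone, is whether pyrazin-2-yl would give a similar step when paired with the piperidin-1-yl amide of compound 3.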